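This account rests on a few compounds, and the source may have more. Where it says the series, first, only, none or still open, it means among the compounds named here.

The set holds three measured compounds and one still to be measured, all sharing the same core. Compound 1 `CCCN(CCC)CCNc1n[n+]([O-])c2ccc(Cl)cc2[n+]1[O-]` carries chloro on an aromatic carbon, and in a physicochemical assay for solubility, in the presence of a further agent that is not named here (a lower number here means a less soluble compound, a higher number a more soluble compound), compound 1 gives 600000 nM. Compound 2 `CCCN(CCC)CCNc1n[n+]([O-])c2ccc(C(C)C)cc2[n+]1[O-]` has isopropyl in place of that chloro, and in this assay compound 2 gives 39000000 nM. The step of a 65-fold higher number from compound 1 to compound 2 (1.81 log units; beyond the scatter) is a large one. Compound 3 `CCN(CC)CCNc1n[n+]([O-])c2ccc(C(C)(C)C)cc2[n+]1[O-]` differs from both in its diethylamino tail. For compound 3 this assay reports only a limit, > 48000000 nM, so compound 3 stands at the upper edge of what this set shows (the limit of > 48000000 nM in this assay, at which 1 of the 3 values shown sits). Compound 4 `CCCN(CCC)CCNc1n[n+]([O-])c2ccc(C(C)(C)C)cc2[n+]1[O-]` differs from compound 3 by dipropylamino in place of diethylamino on a saturated chain carbon, two bonds along the chain from a nitrogen on an aromatic ring. For the measured compounds named here, none of the measured steps concerns this change: the single measured step, a 65-fold higher number from compound 1 to compound 2 (1.81 log units; beyond the scatter), is a change on the aromatic carbon, while compound 1, compound 2 and compound 4 all share the dipropylamino tail. The data therefore give no basis for expecting a step beyond the scatter, and the expected step of a number no higher from compound 3 to compound 4 (the limit leaves the size open) is taken as essentially none. Compound 4 is estimated in this assay at 48000000 nM, within 12000000 nM to 150000000 nM, with a fair chance that only a limit is reported.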

Compound 4, solubility: 32000000 nM
For compound 4 the middle estimate is 1.5-fold (0.18 log units) above the measured one; the range from low to high includes it.
By their numbers in this assay, from the lowest: compound 1; then compounds 4 and 2 (each within the scatter of the next). At a limit, above all of these: compound 3.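

In this assay, from the compounds shown here alone, the tail change from diethylamino to dipropylamino, on a saturated chain carbon, two bonds along the chain from a nitrogen on an aromatic ring, gives an at least 1.5-fold lower number from compound 3 to compound 4 (0.17 log units; that floor lies within the scatter), so no step beyond the scatter can be claimed for it, and its full size stays open. Compound 3 is reported only as a limit: the limit of > 48000000 nM in this assay, at which 1 of the 4 values shown sits.

With the dipropylamino tail held, tert-butyl in place of chloro on the aromatic carbon gives a 53-fold higher number from compound 1 to compound 4 (1.73 log units; beyond the scatter), a second large step from chloro, while methyl in place of hydrogen on the isopropyl group gives a 1.2-fold lower number from compound 2 to compound 4 (0.09 log units; within the scatter), so the compounds shown set no order between isopropyl and tert-butyl.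

The compounds shown leave open whether the tail change would read the same with chloro on the aromatic carbon, and what a dimethylamino tail or a morpholine in its place would give. They also leave open what a group other than chloro, isopropyl and tert-butyl, such as methoxy or a carboxylic acid, would give on that aromatic carbon.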